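A Smaller Ring on the Amide Nitrogen

This account rests on a few compounds, and the source may have more. Where it says the series, first, only, none or still open, it means among the compounds named here.

Compound 1 `N=c1oc2ccc(Br)cc2cc1C(=O)NC1CCCCC1` was tested in an assay on HeLa cells for displacement of a labelled ligand from adenosine receptor A3 (Homo sapiens), read by scintillation counting, with a stated time of 180 min, tested at 10 uM (a lower number here means less inhibition, a higher number more inhibition at the concentration tested (going by the name of the read-out)), where compound 1 gives 8%. Compound 2 `COc1cccc2cc(C(=O)NCC(O)CO)c(=O)oc12`, built on a different core, gives 1% in this assay; the two figures lie within the usual scatter of each other, so neither compound stands apart. Compound 3 `N=c1oc2ccc(Br)cc2cc1C(=O)NC1CCCC1` is compound 1 changed in one place: cyclopentyl in place of cyclohexyl on an amide-type nitrogen. Among the compounds with values here, no measured pair shows what this change does, so only a small step is expected, a number 1 percentage points lower from compound 1 to compound 3 (within the scatter), with nothing beyond the scatter. Compound 3 is therefore estimated at 7%, expected to fall between -5% and 20%.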

Compound 3, a percentage reported as inhibition, at one concentration (the size of the read-out at that concentration, not a potency): 0%
The estimate for compound 3 lay 7 percentage points above the measured number; the measured number falls inside the stated range.
By their numbers in this assay, from the lowest: compounds 3, 2 and 1 (each within the scatter of the next).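

Swapping cyclohexyl for cyclopentyl on an amide-type nitrogen gives the first direct reading at this position: in this assay there is a number 8 percentage points lower from compound 1 to compound 3 (within the scatter), so this change in ring size does not separate the two compounds. At the one concentration tested, the numbers for compound 1 and compound 3 are level, within the scatter. No available evidence bears on this result. On these data alone, it remains open whether a longer chain in place of the ring would move the number beyond the scatter. The same question stands for a ring carrying an amine or a carboxylic acid.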